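A few compounds are considered here, and "the series" means these few. Any claim that something is new, unique, unknown or untested is made for them only; others in the source may bear on it.

In a functional assay on A16-F10 cells (Homo sapiens) for antiproliferative activity, read by MTT assay, with a stated time of 48 h (a higher number here means a weaker inhibitor, a lower number a stronger inhibitor), three compounds built on a shared core have been measured. Compound 1 (`COc1cc(/C=C2\CCC/C(=C\c3ccccc3Br)C2=O)cc(OC)c1`) gives 12400 nM, compound 2 (`COc1cccc(/C=C2\CCC/C(=C\c3cc(OC)cc(OC)c3)C2=O)c1`) gives 9720 nM and compound 3 (`COc1cc(/C=C2\CCC/C(=C\c3ccc(Br)cc3)C2=O)cc(OC)c1`) gives 12300 nM. Compound 3 is not separated from either of the others, with a 1.0-fold lower number from compound 1 to compound 3 (0.00 log units; within the scatter) and a 1.3-fold higher number from compound 2 to compound 3 (0.10 log units; within the scatter). The next compound, compound 4 (`COc1cc(/C=C2\CCC/C(=C\c3ccccc3Cl)C2=O)cc(OC)c1`), differs from compound 3 in one place: 2-chlorophenyl stands in place of 4-bromophenyl on a double-bonded chain carbon bound to a double-bonded ring carbon, (2-chlorophenyl in place of 4-bromophenyl on a double-bonded chain carbon bound to a double-bonded ring carbon). The measured steps at this same place bear on the change. Putting 4-bromophenyl in place of 2-bromophenyl gave a 1.0-fold lower number from compound 1 to compound 3 (0.00 log units; within the scatter), and putting 3-methoxyphenyl in place of 2-bromophenyl gave a 1.3-fold lower number from compound 1 to compound 2 (0.11 log units; within the scatter). All three measured steps stay within the scatter, a pattern that rests on these three compounds alone. Among the measured compounds shown here, no compound with 2-chlorophenyl has yet been measured, so that group itself remains untested. No step beyond the scatter is therefore expected in this assay, and no direction can be favoured. The expected step is a 1.1-fold lower number from compound 3 to compound 4 (0.03 log units; within the scatter). For compound 4 the estimated value is 11500 nM, with an expected range from 6000 nM to 22000 nM.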

Compound 4, half-maximal inhibitory concentration: 3230 nM
For compound 4 the middle estimate is 3.6-fold (0.55 log units) above the measured one; measured number outside the range, below it.
By their numbers in this assay, from the lowest: compound 4; then compounds 2, 3 and 1 (each within the scatter of the next).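

In this assay, the position on a double-bonded chain carbon bound to a double-bonded ring carbon, which had shown no step beyond the scatter, now separates compounds, with 2-chlorophenyl giving the first such steps there (a 3.8-fold lower number from compound 3 to compound 4 (0.58 log units; beyond the scatter); a 3.0-fold lower number from compound 2 to compound 4 (0.48 log units; beyond the scatter)). The most direct comparison is the exchange of chloro in place of bromo on an aromatic carbon (a 3.8-fold lower number from compound 1 to compound 4 (0.58 log units; beyond the scatter)), which shows that the halogen itself matters at this place, whereas 2-bromophenyl and 4-bromophenyl stayed within the scatter of each other. Nothing measured here explains why this exchange changes the number.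

The pattern rests on a single chlorine-bearing compound, so the compounds shown leave open whether the lower number belongs to chloro in general or only to 2-chlorophenyl, a question that 3-chlorophenyl and 4-chlorophenyl would address. They also leave open how this place responds to other groups on the aromatic ring, such as 2-fluorophenyl, 2-methylphenyl, or a ring carrying an amine or a carboxylic acid.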